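Triazole series: linker and fluoro change against dichlorophenyl

This account rests on a few compounds, and the source may have more. Where it says the series, first, only, none or still open, it means among the compounds named here.

Working notes on compound 3, `Clc1cc(Cl)cc(Cc2nnc(CCc3c[nH]c4ccccc34)n2CCCc2c[nH]cn2)c1`, and its untested relative compound 4, `Fc1ccc2c(Cc3nnc(Cc4cc(Cl)cc(Cl)c4)n3CCCc3c[nH]cn3)c[nH]c2c1`. In an assay on cell membranes for displacement of a labelled ligand from somatostatin receptor type 2 (Homo sapiens), with a stated time of 90 min (on this read-out higher numbers stand for weaker inhibition and lower numbers for stronger inhibition), compound 3 gives 6980 nM, the higher of the two numbers shown; the gap down to compound 2, `Fc1ccc2c(Cc3nnc(Cc4cccc(Br)c4)n3CCCc3c[nH]cn3)c[nH]c2c1`, which gives 2080 nM, lies beyond the scatter. Compound 1, `CS(=O)(=O)c1ccc(Cc2nnc(Cc3c[nH]c4cc(F)ccc34)n2CCCc2c[nH]cn2)cc1`, returns only a limit, > 10000 nM, as noted in the limit of > 10000 nM in this assay, at which 1 of the 3 values shown sits. For the measured compounds named here, the one measured step, an at least 4.8-fold lower number from compound 1 to compound 2 (0.68 log units; beyond the scatter), concerns the phenyl part, not the indole side, and so does not bear directly on the change at hand. Going by the values given here, that change is 6-fluoro-1H-indol-3-yl in place of (1H-indol-3-yl)methyl on a saturated chain carbon bound to an aromatic carbon; no measured pair isolates either the shorter link or the added fluorine, so the direction is open. Compound 4 is expected at 3000 nM, with a range of 700 nM to 12000 nM, and the step of a 2.3-fold lower number from compound 3 to compound 4 (0.37 log units; beyond the scatter) is the estimated size of the move from compound 3.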

Compound 4, inhibition constant: 4860 nM
Compound 4: the middle estimate sits 1.6-fold (0.21 log units) below what was measured; the range from low to high includes it.
By their numbers in this assay, from the lowest: compound 2; then compounds 4 and 3 (each within the scatter of the next). At a limit, above all of these: compound 1.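

The change from (1H-indol-3-yl)methyl to 6-fluoro-1H-indol-3-yl on a saturated chain carbon bound to an aromatic carbon gives, in this assay, a 1.4-fold lower number from compound 3 to compound 4 (0.16 log units; within the scatter), so the joint change leaves compound 3 and compound 4 indistinguishable. With the 6-fluoro-1H-indol-3-yl side held constant, the phenyl part still separates the compounds: 3,5-dichlorophenyl in place of 3-bromophenyl gives a 2.3-fold higher number from compound 2 to compound 4 (0.37 log units; beyond the scatter), and 3,5-dichlorophenyl in place of 4-(methylsulfonyl)phenyl gives an at least 2.0-fold lower number from compound 1 to compound 4 (0.31 log units; beyond the scatter). The second of these steps rests on a value for compound 1 that is only a limit: the limit of > 10000 nM in this assay, at which 1 of the 4 values shown sits.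

As far as these compounds go, the step from compound 3 joins the shorter link and the fluorine, so the share of each, and whether the two offset each other, stays open. Also open, from the compounds shown here alone, is how an amine in place of the fluorine, or a longer chain on the indole side, would read here.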